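Nitro in place of methyl on an inactive pair

The source may report more compounds than this note shows. Statements on the series, on what has been measured and on what is new or still open speak of the compounds shown alone.

Compound 2 `CCOC(=O)c1nn(-c2ccc(C)cc2)/c(=N/c2nc(-c3c(C)n(C)n(-c4ccccc4)c3=O)cs2)s1` was examined in a functional assay on A549 cells (Homo sapiens) for cytotoxicity, read by sulforhodamine B assay, with a stated time of 72 h; on this read-out lower numbers stand for stronger inhibition and higher numbers for weaker inhibition. In this assay compound 2 gives > 100000 nM, which is a limit of the assay and not a number. Compound 1 `CC(=O)c1nn(-c2ccc([N+](=O)[O-])cc2)/c(=N/c2nc(-c3c(C)n(C)n(-c4ccccc4)c3=O)cs2)s1` in this assay gives > 100000 nM, also a limit. Both values sit at the same point, (the limit of > 100000 nM in this assay, at which 2 of the 2 values shown sit). Compound 3 `CCOC(=O)c1nn(-c2ccc([N+](=O)[O-])cc2)/c(=N/c2nc(-c3c(C)n(C)n(-c4ccccc4)c3=O)cs2)s1` is not yet measured; it differs from compound 2 by nitro in place of methyl on an aromatic carbon. The expected step from compound 2 to compound 3 in this assay is a step that the limit leaves unreadable from compound 2 to compound 3, nothing beyond the scatter. Compound 3 is estimated at 150000 nM, most likely again a limit, between 70000 nM and 400000 nM.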

Compound 3, half-maximal inhibitory concentration: 8680 nM
Compound 3: the middle estimate sits 17-fold (1.24 log units) above what was measured, and the stated range ends above it.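

In this assay, 4-methylphenyl to 4-nitrophenyl gives an at least 11-fold lower number from compound 2 to compound 3 (1.06 log units; beyond the scatter), so this position, para to a large group, can carry the change from a limit to a measurable value. That gain depends on the neighbouring carbonyl substituent, since ethoxy in place of methyl on the carbonyl carbon gives an at least 11-fold lower number from compound 1 to compound 3 (1.06 log units; beyond the scatter), and the nitro group alone does not reach a measurable value in compound 1. Both steps start from a limit, so their full size stays unknown: the limit of > 100000 nM in this assay, at which 2 of the 3 values shown sit.

The compounds shown leave open whether an amine or a carboxylic acid at this position would keep the value of compound 3. They also leave open how a longer chain in place of ethoxy would fare.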